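The compounds below may be only part of what the source reports. "The series", "measured", "known", "first", "only" and "open" are said of these compounds alone.

Measured so far:
Compound 1, `Cc1nc(-c2ccc(C(F)(F)F)cc2)sc1CNc1ccc(CCC(=O)NC(C)C)cc1`, in a functional assay on CHO cells for agonist activity at Free fatty acid receptor 1 (Homo sapiens), read by a luciferase reporter; on this read-out lower numbers stand for smaller maximal responses and higher numbers for larger maximal responses: 84%
Compound 2, `Cc1nc(-c2ccc(C(F)(F)F)cc2)sc1CNc1ccc([C@H]2C[C@@H]2C(=O)NC2CCNC2)cc1`, in this assay: 52%

Compound 2 gives the lower of the two numbers seen. Going by the values given here, its nearest neighbour is compound 1, and the one recorded step, a number 32 percentage points lower from compound 1 to compound 2 (beyond the scatter), is beyond the scatter; it replaced 2-(isopropylcarbamoyl)ethyl with 2-((pyrrolidin-3-yl)carbamoyl)cyclopropyl on an aromatic carbon. Compound 3, `Cc1nc(-c2ccc(C(F)(F)F)cc2)sc1CNc1ccc([C@H]2C[C@@H]2C(=O)NO)cc1`, has not been measured. It differs from compound 2 by hydroxy in place of pyrrolidin-3-yl on an amide-type nitrogen. Among the compounds with values here, no measured step touches this position alone: the step from compound 1 to compound 2 altered the chain and what sits on the amide-type nitrogen at once, so it says little about exchanging the group on that nitrogen by itself. With nothing in the data speaking for a rise or a fall, the change is expected to give a number 2 percentage points lower from compound 2 to compound 3 (within the scatter), a step within the scatter, though the uncertainty is wide. For compound 3 the estimate in this assay is 50%, with a range from 25% to 80%.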

Compound 3, largest response reached (reported as percent of maximum), in percent of the reference or control that the assay uses: 78%
Beside the measured number, compound 3's estimate is 28 percentage points below it, and the stated range covers the measured number.
By their numbers in this assay, from the lowest: compound 2; then compounds 3 and 1 (each within the scatter of the next).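

In this assay, the group on the amide-type nitrogen proves to matter on its own: with the cyclopropyl kept, hydroxy in place of pyrrolidin-3-yl gives a number 26 percentage points higher from compound 2 to compound 3 (beyond the scatter), an effect that the earlier step could not separate from the change of chain. The step of a number 6 percentage points lower from compound 1 to compound 3 (within the scatter) places 2-(hydroxycarbamoyl)cyclopropyl and 2-(isopropylcarbamoyl)ethyl on the aromatic carbon within the scatter of each other, so the cyclopropyl does not by itself go with a smaller maximal response, and the lower number of compound 2 follows the pyrrolidin-3-yl group in this set. Nothing available explains why the exchange on this nitrogen moves the response as it does.

The compounds shown leave open whether the lower response goes with the ring amine of pyrrolidin-3-yl or with the ring as such, a question that a cyclopentyl group or an open-chain aminoethyl group on the same nitrogen would address. They also leave open how a hydroxycarbamoyl group would read on the ethyl chain of compound 1, and how a carboxylic acid would compare with it on the cyclopropyl.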